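Pyrazole Series: Pyridyl Ether Replaces Chlorophenyl

The source may hold more compounds than are shown below. What is called first, only, known or untested is meant among the compounds shown, and "the series" means these compounds.

Measured compounds:
compound 1, `COc1ccccc1-n1nc(C2CC(C)(C)OC(C)(C)C2)cc1-c1ccc(Cl)cc1`, 16 nM
compound 2, `COc1ccccc1-n1nc([C@@H]2CCO[C@@H](C(C)C)C2)cc1-c1ccc(Cl)cc1`, "not determined" (no result reported)

Among the compounds with values here, compound 1 gives the only number in an assay on HEK293 cells for inhibition of Voltage-dependent N-type calcium channel subunit alpha-1B (Homo sapiens), read by patch clamp, using a membrane potential dye; a lower number here means a stronger inhibitor, a higher number a weaker inhibitor; compound 2 carries no result in this assay, so compound 1 stands alone and cannot be ranked against another measured entry. Compound 3, `CCOc1ccc(-c2cc(C3CC(C)(C)OC(C)(C)C3)nn2-c2ccccc2OC)cn1`, differs from compound 1 by 6-ethoxypyridin-3-yl in place of 4-chlorophenyl on an aromatic carbon. Within the data shown here, no pair of measured compounds shows what a change of this kind does in this assay, so the size of the step is uncertain. Compound 3 is expected to be a weaker inhibitor than compound 1 by a 2.5-fold higher number from compound 1 to compound 3 (0.40 log units; beyond the scatter), a step slightly beyond the scatter. The estimate for compound 3 in this assay is 40 nM, within a range from 10 nM to 160 nM.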

Compound 3, half-maximal inhibitory concentration: 44 nM
Beside the measured number, compound 3's estimate is 1.1-fold (0.04 log units) below it; measured number inside the range.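

In this assay, within the data shown here, placing 6-ethoxypyridin-3-yl in place of 4-chlorophenyl on this aromatic carbon gives a 2.8-fold higher number from compound 1 to compound 3 (0.44 log units; beyond the scatter) and is the first measured step at this position. The position therefore keeps inhibition in the nanomolar range with a ring holding a hetero atom and an ethoxy group, at a modest cost. Nothing given here explains the size of this step.

Still open, from the compounds shown here alone, is whether the step belongs to the ring nitrogen or to the ethoxy group. Also open, going by these compounds, is how a methoxy group or an amine in place of the ethoxy group would read in this assay at this position.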